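From a Phenoxybutyl Ester to an Indolyl Chain

The source may report more compounds than this note shows. Statements on the series, on what has been measured and on what is new or still open speak of the compounds shown alone.

Measured compounds:
compound 1 `O=C(CCCCOc1ccccc1)OCC1COCCOCCOCCOCCOCCO1` — > 100000 nM
compound 2 `O=C(OCC1COCCOCCOCCOCCOCCO1)c1cccc(-c2ccc(Br)cc2)c1` — 4400 nM
compound 3 `O=C(/C=C/c1ccccc1)OCC1COCCOCCOCCOCCOCCO1` — 48000 nM

In a functional assay on SW1573 cells (Homo sapiens) for inhibition, read by sulforhodamine B assay, with a stated time of 48 h (on this read-out higher numbers stand for weaker inhibition of growth and lower numbers for stronger inhibition of growth), compound 1 gives only a limit, > 100000 nM. Compound 2 gives 4400 nM and compound 3 gives 48000 nM in this assay, so compound 1 sits at the weak end of the three values shown.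

The unmeasured compound 4 `O=C(CCCc1cc2ccccc2[nH]1)OCC1COCCOCCOCCOCCOCCO1` differs from compound 1 in one place: 1H-indol-2-yl in place of phenoxymethyl on a saturated chain carbon, three bonds along the chain from a carbonyl carbon.

Within the data shown here, only one measured step bears on this change, an at least 2.0-fold lower number from compound 1 to compound 3 (0.31 log units; beyond the scatter), where an aromatic group was brought closer to the carbonyl carbon. That step, resting on (the limit of > 100000 nM in this assay, at which 1 of the 3 values shown sits), shows that moving away from the phenoxybutyl chain of compound 1 can lower the number, but only its lower bound is known. Compound 4 keeps a three-carbon chain and places 1H-indol-2-yl at its end, a change of a similar kind though not the same.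

The step of an at least 1.6-fold lower number from compound 1 to compound 4 (0.22 log units; that floor lies within the scatter) is therefore expected to be modest and downward, with a real chance that compound 4 again returns only a limit. Compound 4 is estimated at 60000 nM in this assay, between 15000 nM and 200000 nM.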

Compound 4, concentration for 50% growth inhibition: > 100000 nM
Compound 4: a limit, no number; the forecaster's own chance of this, stated with the estimate: 40%; middle value at least 1.6-fold (0.22 log units) from the limit.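

In this assay compound 4 gives the limit > 100000 nM and no number. Among these compounds, compound 1 also stands at a limit, so no step from compound 1 to compound 4 can be read. The compounds shown leave open whether 1H-indol-2-yl in place of phenoxymethyl changes growth inhibition at all, and in which direction.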